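The compounds below may be only part of what the source reports. "The series", "measured", "known", "first", "only" and "open" are said of these compounds alone.

Working notes on the series. Three measured compounds share one core and differ only in the group carried on the outer aryl ring. In an assay on cells for inhibition of ubiquitin carboxyl-terminal hydrolase isozyme L5 (Homo sapiens), read by fluorescence, with a stated time of 30 min (a higher number here means a weaker inhibitor, a lower number a stronger inhibitor), compound 1 `O=C(O)c1cc(Cn2cc(-c3ccc(NCc4ccccc4)cc3)nn2)cc(-c2ccccc2C(=O)O)c1` gives 215000 nM. Compound 2 `CC(=O)Nc1cccc(-c2cn(Cc3cc(C(=O)O)cc(-c4ccccc4C(=O)O)c3)nn2)c1` gives 96200 nM in this assay. Compound 3 `Nc1ccc(-c2cn(Cc3cc(C(=O)O)cc(-c4ccccc4C(=O)O)c3)nn2)cc1` gives 80500 nM in this assay, the lowest of the three numbers, though its gap to compound 2 is within the scatter and only its gap to compound 1 is beyond it. The two steps into compound 3 are a 2.7-fold lower number from compound 1 to compound 3 (0.43 log units; beyond the scatter) and a 1.2-fold lower number from compound 2 to compound 3 (0.08 log units; within the scatter).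

Compound 4 `NS(=O)(=O)Nc1ccc(-c2cn(Cc3cc(C(=O)O)cc(-c4ccccc4C(=O)O)c3)nn2)cc1` is not yet measured. It differs from compound 3 by sulfamoyl in place of hydrogen on a nitrogen on an aromatic ring. Among the measured compounds shown here, no measured step puts a sulfamoyl on this nitrogen, so neither bears on it directly. The step of a 2.7-fold lower number from compound 1 to compound 3 (0.43 log units; beyond the scatter) touches the same nitrogen and shows that a benzyl there is modestly worse than hydrogen. The step of a 1.2-fold lower number from compound 2 to compound 3 (0.08 log units; within the scatter) shows that a substituted nitrogen at another position of the ring costs nothing beyond the scatter. On that basis the expected step of a 1.2-fold lower number from compound 3 to compound 4 (0.06 log units; within the scatter) in this assay is no larger than modest, with direction uncertain. Compound 4 is therefore estimated at 70000 nM, within 20000 nM to 250000 nM.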

Compound 4, half-maximal inhibitory concentration: 84500 nM
Estimate against measurement, compound 4: 1.2-fold (0.08 log units) below; measured number inside the range.
By their numbers in this assay, from the lowest: compounds 3, 4 and 2 (each within the scatter of the next); then compound 1.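

Among the compounds shown here, on the nitrogen on an aromatic ring, the step of a 1.0-fold higher number from compound 3 to compound 4 (0.02 log units; within the scatter) in this assay shows that sulfamoyl, with its 4 heavy atoms, and hydrogen cannot be told apart, a comparison the earlier compounds offered for no group but benzyl. The step of a 2.5-fold lower number from compound 1 to compound 4 (0.41 log units; beyond the scatter) is close in size to the step of a 2.7-fold lower number from compound 1 to compound 3 (0.43 log units; beyond the scatter), so among hydrogen, sulfamoyl and benzyl on this nitrogen, only benzyl stands apart beyond the scatter, and it gives the higher number. The step of a 1.1-fold lower number from compound 2 to compound 4 (0.06 log units; within the scatter) also leaves 4-(sulfamoylamino)phenyl and 3-acetamidophenyl indistinguishable, and no available data explain why these groups read alike.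

Going by these compounds, whether this nitrogen gives the same reading with a small methyl, an acetyl or a methanesulfonyl group remains open, as does whether a longer chain ending in a carboxylic acid would separate from hydrogen in either direction. The compounds shown also leave open whether sulfamoylamino on the ring position held by the acetamido group of compound 2 would read like compound 4, since position and group change together in that comparison.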